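The source may report more compounds than this note shows. Statements on the series, on what has been measured and on what is new or still open speak of the compounds shown alone.

Compound 1 `O=C(CN(c1ncnc2c1ncn2C1CCCCO1)C1CC1)N[C@@H](CCC(=O)OCc1ccccc1)C(=O)OCc1ccccc1`: 34.7%
Compound 2 `O=C(CN(c1nc(Cl)nc2[nH]cnc12)C1CC1)N[C@@H](CO)C(=O)O`: 39.8%

Of the compounds shown here, two have been tested in a functional assay on the whole organism (Tail, strain ICR) with Mus musculus as the target, in the tail flick test, with a stated time of 60 min, at a dose of 25 umol/kg by the oral route; a higher number here means a stronger effect of the compound at the dose given, a lower number a weaker effect. In this assay compound 1 gives 34.7%, and compound 2 gives 39.8%; these two numbers lie within the usual scatter of each other, so neither compound can be told apart from the other on this evidence. Compound 3 `CC[C@H](C)[C@H](NC(=O)CN(c1ncnc2c1ncn2C1CCCCO1)C1CC1)C(=O)OCc1ccccc1` has not yet been measured. It differs from compound 1 in one place (sec-butyl in place of 2-(benzyloxycarbonyl)ethyl on a saturated chain carbon bound to an amide-type nitrogen and a carbonyl carbon). No measured pair shows what such a change does in this assay, so there is no shown step to lean on. For the measured compounds named here, with only two close numbers to go by, the step from compound 1 to compound 3 is expected to stay within the scatter, in no particular direction, which means a number 0.3 percentage points higher from compound 1 to compound 3 (within the scatter). Compound 3 is therefore expected to give about 35%, most likely between 15% and 55%.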

Compound 3, a percentage reported as activity, at one dose (the size of the read-out at that dose, not a potency): 27.4%
Beside the measured number, compound 3's estimate is 7.6 percentage points above it; the range from low to high includes it.
By their numbers in this assay, from the lowest: compounds 3, 1 and 2 (each within the scatter of the next, the first and the last beyond it).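

In this assay, for the compounds shown here, the step at this position, a number 7.3 percentage points lower from compound 1 to compound 3 (within the scatter), gives a first reading of how much this place tolerates. Sec-butyl replaces 2-(benzyloxycarbonyl)ethyl on a saturated chain carbon bound to an amide-type nitrogen and a carbonyl carbon, so the group falls from 12 heavy atoms to 4 and loses its six-membered aromatic ring and both hydrogen-bond acceptors, yet the step stays within the usual scatter. Nothing measured here accounts for this result.

The compounds shown leave open what a free carboxylic acid or an amine on the chain at this place would do to the read-out. A longer unbranched carbon chain or a plain benzyl group at the same place also remains an open question.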